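The compounds below may be only part of what the source reports. "The series", "measured", "known", "first", "only" and "open" are said of these compounds alone.

Of the compounds shown here, three sharing one core have been measured in an ADME assay on L6 cells (Rattus norvegicus) for cytotoxicity, read by fluorescence, with a stated time of 72 h; on this read-out higher numbers stand for weaker inhibition and lower numbers for stronger inhibition. Compound 1 `CC(C)(C)n1nnnc1C(c1ccc(CO[C@@H]2COc3nc([N+](=O)[O-])cn3C2)cc1)N1CCCC1` carries a pyrrolidin-1-yl group on the saturated chain carbon that joins the tetrazole and the benzene ring; in this assay compound 1 gives 75200 nM. Compound 2 `CC(C)(C)n1nnnc1C(NCCCNc1ccnc2cc(Cl)ccc12)c1ccc(CO[C@@H]2COc3nc([N+](=O)[O-])cn3C2)cc1` gives 41500 nM, and compound 3 `CC(C)(C)n1nnnc1C(NCCNc1ccnc2cc(Cl)ccc12)c1ccc(CO[C@@H]2COc3nc([N+](=O)[O-])cn3C2)cc1` gives 24600 nM. Among the measured compounds shown here, of the three numbers, the one for compound 1 is the highest; the gap to compound 2 lies within the usual scatter, so the two readings cannot be told apart, while the gap to compound 3 lies beyond the scatter, so compound 3 shows a lower number than compound 1.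

The step followed here goes from compound 1 to compound 4 `CCN(CC)C(c1ccc(CO[C@@H]2COc3nc([N+](=O)[O-])cn3C2)cc1)c1nnnn1C(C)(C)C`, which has not yet been measured in this assay. The change is diethylamino in place of pyrrolidin-1-yl on a saturated chain carbon bound to two aromatic carbons. Both groups have the same count of heavy atoms and the same count of donors and acceptors; only the ring is lost. For the measured compounds named here, no comparable step is available among the measured compounds, so the expectation rests on this likeness alone. The step from compound 1 to compound 4 in this assay is expected to be a 1.1-fold lower number from compound 1 to compound 4 (0.03 log units; within the scatter), that is, none beyond the scatter. Compound 4 is therefore estimated at 70000 nM, in the range 30000 nM to 160000 nM.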

Compound 4, half-maximal inhibitory concentration: 113000 nM
Compound 4: middle estimate off by 1.6-fold (0.21 log units), on the low side, and the stated range covers the measured number.
By their numbers in this assay, from the lowest: compounds 3, 2, 1 and 4 (each within the scatter of the next, the first and the last beyond it).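

In this assay, diethylamino in place of pyrrolidin-1-yl on a saturated chain carbon bound to two aromatic carbons gives a 1.5-fold higher number from compound 1 to compound 4 (0.18 log units; within the scatter), so the two readings cannot be told apart. This is the first step among the compounds shown that changes only one place, which allows a direct comparison on this carbon: here, the ring of pyrrolidin-1-yl is lost while the counts of heavy atoms, donors and acceptors stay the same, and no difference can be read in this assay. No measurement on hand accounts for this result or tells what either group does in these cells.

The compounds shown leave open whether a group that differs more from pyrrolidin-1-yl on this carbon, such as a piperidin-1-yl ring, a morpholin-4-yl ring or a carboxylic acid, would give a reading beyond the scatter of compound 1. They also leave open whether the same exchange of pyrrolidin-1-yl for diethylamino would stay within the scatter on a different core, or whether a smaller amine such as dimethylamino would do so on this one.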